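Turning One Double Bond from Z to E

The source may hold more compounds than are shown below. What is called first, only, known or untested is meant among the compounds shown, and "the series" means these compounds.

In a functional assay on WiDr cells (Homo sapiens) for antiproliferative activity, read by sulforhodamine B assay, with a stated time of 48 h (a higher number here means a weaker inhibitor of growth, a lower number a stronger inhibitor of growth), compound 3 `COC(=O)/C=C\[C@H]1OCCC[C@H]1O[Si](C)(C)C(C)(C)C` gives 38000 nM. Two close relatives frame that number. Compound 2 `CC(C)(C)[Si](C)(C)O[C@@H]1CCCO[C@@H]1/C=C\C(=O)OCc1ccccc1` gives 20000 nM, and compound 1 `CC(C)(C)[Si](C)(C)O[C@@H]1CCCO[C@@H]1/C=C/C(=O)OCc1ccccc1` gives 90000 nM. Compound 3 sits level with compound 2, which carries phenyl where compound 3 has hydrogen: the move between them is a 1.9-fold higher number from compound 2 to compound 3 (0.28 log units; within the scatter). Compound 1 stands apart with the highest number of the three, and in this assay a higher number means weaker growth inhibition.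

The untested partner of compound 3 is compound 4 `COC(=O)/C=C/[C@H]1OCCC[C@H]1O[Si](C)(C)C(C)(C)C`. The change is the two compounds have the same atoms and bonds and differ only in configuration as drawn: 1 of 3 stereo elements differ; a double bond is drawn Z in compound 3 and E in compound 4. Among the measured compounds shown here, only one measured step bears directly on this switch, and it runs the opposite way, from E to Z: a 4.5-fold lower number from compound 1 to compound 2 (0.65 log units; beyond the scatter). That step can be tied to the double bond alone because of the fact that compounds 1 and 2 differ only in the configuration as drawn. Going from Z to E should therefore raise the number in this assay, by a similar but somewhat smaller amount, as a single pair is thin support. The expected change is a 2.9-fold higher number from compound 3 to compound 4 (0.46 log units; beyond the scatter). Compound 4 is estimated at 110000 nM, with an expected range of 45000 nM to 250000 nM.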

Compound 4, concentration for 50% growth inhibition: > 100000 nM
Compound 4 gave a limit, no number; the forecaster's own chance of this, stated with the estimate: 15%; the middle value is on the limit's open side.
By their numbers in this assay, from the lowest: compounds 2 and 3 (each within the scatter of the next); then compound 1. At a limit, above all of these: compound 4.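

The value of compound 4 in this assay, > 100000 nM, is a limit and not a number. Even so, the switch from Z to E now raises the number on a second ester, with an at least 2.6-fold higher number from compound 3 to compound 4 (0.42 log units; beyond the scatter), matching the reverse switch on the benzyl ester pair, and this new step can be laid on the double bond alone: the fact that compounds 3 and 4 differ only in the configuration as drawn. The swap of hydrogen for phenyl is less settled among the E compounds, where an at least 1.1-fold higher number from compound 1 to compound 4 (0.04 log units; that floor lies within the scatter) gives only a floor, so its size cannot be set against the same swap among the Z compounds: the same change on two cores in this assay, a 1.9-fold higher number (0.28 log units; within the scatter) from compound 2 to compound 3 and an at least 1.1-fold higher number (0.04 log units; that floor lies within the scatter) from compound 1 to compound 4; the limit leaves it open whether they differ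

Going by these compounds, how far compound 4 lies past its limit remains unknown, so the Z-to-E step on this ester cannot be compared in size with the one on the benzyl ester. Also open, on these data alone, is whether Z still gives the lower number when the ester gives way to a carboxylic acid or an amide, or when the silyl ether gives way to a free hydroxyl.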